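A few compounds are considered here, and "the series" means these few. Any claim that something is new, unique, unknown or untested is made for them only; others in the source may bear on it.

Measured compounds:
compound 1 `COCOc1cc(/C=C/C(=O)OCC(=O)Nc2ccc(OC)cc2)ccc1OCc1ccccc1`: > 200000 nM
compound 2 `COc1ccc(NC(=O)COC(=O)/C=C/c2ccc(OCc3ccccc3)c(O)c2)cc1`: > 200000 nM

In a functional assay on HL-60 cells (Homo sapiens) for cytotoxicity, read by MTT assay, with a stated time of 72 h (a higher number here means a weaker inhibitor, a lower number a stronger inhibitor), compound 1 gives > 200000 nM, which is a limit of the assay and not a number. Compound 2 gives > 200000 nM, again a limit rather than a measured figure. Both values sit at the limit of > 200000 nM in this assay, at which 2 of the 2 values shown sit. Within the data shown here, the only step between measured compounds, a step that the two limits leave unreadable from compound 1 to compound 2, therefore cannot be read in size or direction; compound 1 stands nowhere more precise than at that limit.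

Compound 3 `COCOc1cc(/C=C/C(=O)OCC(=O)Nc2nccs2)ccc1OCc1ccccc1` differs from compound 1 by 1,3-thiazol-2-yl in place of 4-methoxyphenyl on an amide-type nitrogen. Among the measured compounds shown here, no measured step touches the group on the amide-type nitrogen, and the single step that is known concerns a different place and is itself unreadable. The expectation for compound 3 thus rests on compound 1 alone. Compound 3 is expected to give about 200000 nM in this assay, within a range of 30000 nM to 1000000 nM. The step from compound 1 to compound 3, a number no higher from compound 1 to compound 3 (the limit leaves the size open), is estimated as none beyond the scatter, and most likely the assay will again report only a limit.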

Compound 3, half-maximal inhibitory concentration: > 200000 nM
Compound 3: no number, only a limit; the forecaster's own chance of this, stated with the estimate: 80%; the middle value sits exactly at the limit.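

In this assay compound 3 gives > 200000 nM, which is a limit of the assay and not a number. No new step can be read, as compound 1 and compound 3 both stand only at a limit: the limit of > 200000 nM in this assay, at which 3 of the 3 values shown sit. The compounds shown leave open what value, if any, could be measured for this series.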